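The source may report more compounds than this note shows. Statements on the series, on what has been measured and on what is new or still open speak of the compounds shown alone.

Compound 1, `Cc1cc(-c2ccccc2)n(Cc2n[nH]c(=S)o2)n1`: 26.3%
Compound 2, `COc1ccc(NC(=S)NNC(=O)Cn2nc(C)cc2C)cc1`: 30.3%

In a functional assay on the whole organism (strain albino) for inhibition, with Rattus norvegicus as the target, read by paw edema, with a stated time of 1 h, at a dose of 100 mg/kg by the oral route (on this read-out higher numbers stand for more inhibition at the one dose given (going by the name of the read-out) and lower numbers for less inhibition), compound 2 stands at the top of the two numbers, yet its gap to compound 1 lies within the scatter, so the two are not told apart. Compound 3, `Cc1cc(C)n(CC(=O)NNC(=S)Nc2ccc([N+](=O)[O-])cc2)n1`, differs from compound 2 in a single place: nitro in place of methoxy on an aromatic carbon. Going by the values given here, no measured pair shows what such a change does here, so there is nothing to set its size. A step of a number 0.3 percentage points lower from compound 2 to compound 3 (within the scatter) is expected, no larger than the scatter in either direction. Compound 3 is therefore estimated at 30%, between 18% and 42%.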

Compound 3, a percentage reported as inhibition, in the whole organism at one dose (the size of the read-out at that dose, not a potency): 36.1%
For compound 3 the middle estimate is 6.1 percentage points below the measured one, and the stated range covers the measured number.
By their numbers in this assay, from the lowest: compounds 1, 2 and 3 (each within the scatter of the next).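

On the aromatic carbon para to a large group, nitro in place of methoxy gives a number 5.8 percentage points higher from compound 2 to compound 3 (within the scatter) in this assay and so leaves the two compounds not told apart. Going by these compounds alone, this is the first measured step at this place, and at this one dose the two groups serve about equally well despite their different atoms. Nothing measured here speaks to the reason for this result.

As far as these compounds go, what an amine or a carboxylic acid on this same carbon would do remains open. From the compounds shown here alone, whether other doses would separate compound 2 and compound 3 also remains open.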